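Chain Shortening on Two Cores: Gastric Inhibition

The source may hold more compounds than are shown below. What is called first, only, known or untested is meant among the compounds shown, and "the series" means these compounds.

The study follows a small set of thioamide-bearing compounds in a functional assay on the whole organism (stomach) for inhibition, with Rattus norvegicus as the target, at a dose of 100 mg/kg by the intraduodenal route; on this read-out higher numbers stand for more inhibition at the one dose given (going by the name of the read-out) and lower numbers for less inhibition. Compound 1, `N=C(S)CCCCCCn1nc(-c2ccccc2)ccc1=O`, gives 33.9% in this assay. Compound 2, `N=C(S)CCCCCn1nc(-c2ccccc2)ccc1=O`, gives 91.4% in this assay. The two differ in one place: a group of 3 heavy atoms (1 carbon, 1 nitrogen, 1 sulfur; no ring) in place of a group of 4 heavy atoms (2 carbon, 1 nitrogen, 1 sulfur; no ring), on a saturated chain carbon, five bonds along the chain from an aromatic nitrogen. The measured step is a number 57.5 percentage points higher from compound 1 to compound 2 (beyond the scatter), and it is the only single-place step measured among these compounds.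

Compound 3, `Cc1ccc(=O)n(CCCCC(=N)S)n1`, carries a different core; the difference between the two cores is not broken down here. In this assay compound 3 gives 29.5%, a number near that of compound 1 and far below that of compound 2.

Compound 4, `Cc1ccc(=O)n(CCCC(=N)S)n1`, has not yet been measured in this assay. It differs from compound 3 by a group of 3 heavy atoms (1 carbon, 1 nitrogen, 1 sulfur; no ring) in place of a group of 4 heavy atoms (2 carbon, 1 nitrogen, 1 sulfur; no ring), on a saturated chain carbon, three bonds along the chain from an aromatic nitrogen. This is the same kind of change as between compound 1 and compound 2, but not the same: in the earlier pair the chain carbon lies five bonds along the chain from an aromatic nitrogen, whereas here it lies three bonds along the chain from an aromatic nitrogen. Because the earlier shortening produced the step of a number 57.5 percentage points higher from compound 1 to compound 2 (beyond the scatter), compound 4 is expected to gain on compound 3, while the different core and the different place argue for a smaller gain. The expected step is a number 22.5 percentage points higher from compound 3 to compound 4 (beyond the scatter). Compound 4 is estimated at 52%, within an expected range from 18% to 86%.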

Compound 4, a percentage reported as inhibition, in the whole organism at one dose (the size of the read-out at that dose, not a potency): 36.3%
Beside the measured number, compound 4's estimate is 15.7 percentage points above it, and the stated range covers the measured number.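

Among the compounds shown here, on the second core, the shortening in this assay comes to a number 6.8 percentage points higher from compound 3 to compound 4 (within the scatter), so on this core the change leaves no step that can be told from the usual spread of repeated measurements. For the compounds shown here, the large gain seen on the core of compound 1 therefore did not carry over to the core of compound 3 at anything like its size: the same change on two cores in this assay, a number 57.5 percentage points higher (beyond the scatter) from compound 1 to compound 2 and a number 6.8 percentage points higher (within the scatter) from compound 3 to compound 4, 50.7 percentage points apart, beyond the scatter of two such steps This does not show that the core alone sets the size of the step, since the two changes also lie at different places, one five bonds and the other three bonds along the chain from an aromatic nitrogen, and the two pairs cannot separate the core from the chain length; with only two pairs, each read at a single dose, they also give no general rule for the series.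

The compounds shown leave open what a longer chain on the core of compound 3 or a shorter chain on the core of compound 1 would give, either of which would help set the two cores side by side at a matching chain length. They also leave open whether an amide, a nitrile or a carboxylic acid in place of the thioamide group would keep the inhibition of compound 2 at 91.4%.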